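A few compounds are considered here, and "the series" means these few. Any claim that something is new, unique, unknown or untested is made for them only; others in the source may bear on it.

Compound 2 `CNc1nc(NC2(C#N)CCCCC2)nc(OC)n1` gives 196 mL/min/kg in an ADME assay on microsomes from liver (Rattus norvegicus) for metabolic stability (a higher number here means faster removal of the compound, a lower number slower removal), and lies within the scatter of compound 1 `CNc1nc(NC2(C#N)CCCCC2)nc(-n2cccn2)n1` at 103 mL/min/kg on this read-out. The next structure, compound 3 `CNc1nc(Cl)nc(NC2(C#N)CCCCC2)n1`, carries chloro in place of methoxy on an aromatic carbon, opposite the ring nitrogen (chloro in place of methoxy on an aromatic carbon). Within the data shown here, only one measured step bears on this carbon: a 1.9-fold higher number from compound 1 to compound 2 (0.28 log units; within the scatter) for methoxy in place of 1H-pyrazol-1-yl on an aromatic carbon. Among the measured compounds shown here, no chloro compound has been measured on this core, so that single step is a weak guide. On that evidence, no step beyond the scatter is expected in this assay for this change, and the estimated shift is a 1.5-fold lower number from compound 2 to compound 3 (0.18 log units; within the scatter) at most a working figure. For compound 3 the expected clearance is 130 mL/min/kg (estimated range 60 mL/min/kg to 280 mL/min/kg).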

Compound 3, clearance: 867 mL/min/kg
Beside the measured number, compound 3's estimate is 6.7-fold (0.82 log units) below it, and the stated range ends below it.
By their numbers in this assay, from the lowest: compounds 1 and 2 (each within the scatter of the next); then compound 3.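

In this assay, the substituent on this aromatic carbon, between two ring nitrogen atoms, now proves able to shift the read-out: replacing methoxy with chloro gives a 4.4-fold higher number from compound 2 to compound 3 (0.65 log units; beyond the scatter), and replacing 1H-pyrazol-1-yl with chloro gives an 8.4-fold higher number from compound 1 to compound 3 (0.93 log units; beyond the scatter). The earlier pair, methoxy and 1H-pyrazol-1-yl, lay within the scatter of each other and gave no such sign; of the three groups, chloro alone stands apart, with both of its steps beyond the scatter. No measurement at hand accounts for the higher clearance with chloro.

Going by these compounds, it remains open whether an amine or ethoxy on this carbon would stay with methoxy and 1H-pyrazol-1-yl or move towards chloro. On these data alone, whether the chloro step holds with a different group in place of the methylamino group is also open.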